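A few compounds are considered here, and "the series" means these few. Any claim that something is new, unique, unknown or untested is made for them only; others in the source may bear on it.

Compound 1 `COc1ccccc1-c1ccc(CNc2nc(NC3CCC(N)CC3)nc3c2ncn3C2CCCC2)cc1`: 347 nM
Compound 2 `NC1CCC(Nc2nc(NCc3ccc(-n4cccn4)cc3)c3ncn(C4CCCC4)c3n2)CC1`: 119 nM

In a functional assay on K562 cells (Homo sapiens) for inhibition, with a stated time of 72 h (on this read-out lower numbers stand for stronger inhibition and higher numbers for weaker inhibition), compound 2 holds the lower of the two numbers, 119 nM. Within the data shown here, the only measured step is a 2.9-fold lower number from compound 1 to compound 2 (0.46 log units; beyond the scatter), and it comes from 1H-pyrazol-1-yl in place of 2-methoxyphenyl on an aromatic carbon.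

Compound 3 `NC1CCC(Nc2nc(NCc3ccc(-c4ccccc4O)cc3)c3ncn(C4CCCC4)c3n2)CC1` differs from compound 2 in one place, with 2-hydroxyphenyl in place of 1H-pyrazol-1-yl on an aromatic carbon. Among the measured compounds shown here, this brings back a substituted phenyl group, much like the 2-methoxyphenyl of compound 1, so that single modest step is the only guide. For the measured compounds named here, it is thin evidence, since no measurement yet shows how 2-hydroxyphenyl itself behaves. A move back toward compound 1 at 347 nM is expected, probably not all the way. The estimated change is a 2.1-fold higher number from compound 2 to compound 3 (0.32 log units; beyond the scatter), toward weaker inhibition and smaller than the measured step. For compound 3 the expected value is 250 nM, with an estimated range of 90 nM to 700 nM.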

Compound 3, half-maximal inhibitory concentration: 2610 nM
Compound 3: middle estimate off by 10-fold (1.02 log units), on the low side, outside the stated range (above it).
By their numbers in this assay, from the lowest: compound 2; then compound 1; then compound 3.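

In this assay, the group on this aromatic carbon turns out to matter far more than the first measured step suggested: going from 1H-pyrazol-1-yl to 2-hydroxyphenyl gives a 22-fold higher number from compound 2 to compound 3 (1.34 log units; beyond the scatter), a large change toward weaker inhibition. The more telling comparison lies within the phenyl groups, where removing only the methyl from the oxygen of 2-methoxyphenyl gives a 7.5-fold higher number from compound 1 to compound 3 (0.88 log units; beyond the scatter). A substituted phenyl ring at this place therefore does not settle the number by itself, since an edit of a single atom on the ring's oxygen is enough to move it well beyond the usual scatter. Nothing measured here bears on why either change shifts the number so much.

Among these compounds, with only three compounds, it remains open whether the loss is specific to the free hydroxyl, or whether an amine or a fluorine in its place on the same phenyl ring would also give a high number. Going by these compounds, it is equally open whether another five-membered aromatic ring, such as imidazole, would match or improve on compound 2 at 119 nM.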